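A few compounds are considered here, and "the series" means these few. Any claim that something is new, unique, unknown or untested is made for them only; others in the source may bear on it.

In a functional assay on U-373MG ATCC cells for cytotoxicity against U373 MG (Homo sapiens), read by colorimetric assay and MTT assay (on this read-out higher numbers stand for weaker inhibition and lower numbers for stronger inhibition), compound 1 `COc1ccc(-c2cc3c(OC)cc(OC)cc3n(CC#N)c2=O)cc1` gives 10000 nM. Compound 2 `COc1ccc(-c2cc3c(OC)cc(OC)cc3n(CCCC#N)c2=O)cc1` gives 10000 nM. Compound 3 `COC(=O)CCn1c(=O)c(-c2ccc(OC)cc2)cc2c(OC)cc(OC)cc21`, which carries a methoxycarbonyl group at the end of its chain, gives 10000 nM, so it stands level with the other two.

Compound 4 `COc1ccc(-c2cc3c(OC)cc(OC)cc3n(CCC#N)c2=O)cc1` has not yet been measured. It has cyano in place of methoxycarbonyl on a saturated chain carbon, two bonds along the chain from an aromatic nitrogen.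

All three measured steps bear on this change. The one closest to it alters the same chain carbon and shows no change at the digits printed from compound 2 to compound 3 (within the scatter). The other two show no change at the digits printed from compound 1 to compound 3 (within the scatter) and no change at the digits printed from compound 1 to compound 2 (within the scatter). None of these chain changes moved the read-out, although three compounds are a narrow base. No step beyond the scatter is therefore expected in this assay.

The expected result is no change at the digits printed from compound 3 to compound 4 (within the scatter). For compound 4 the estimated value is 10000 nM, with an expected range of 5000 nM to 15000 nM.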

Compound 4, half-maximal inhibitory concentration: 10000 nM
For compound 4 middle estimate and measured number coincide at the digits printed; measured number inside the range.
By their numbers in this assay, from the lowest: compounds 1, 2, 3 and 4 (each within the scatter of the next).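

In this assay, the swap of methoxycarbonyl for cyano at the chain end gives no change at the digits printed from compound 3 to compound 4 (within the scatter), so on this chain the nitrile and the ester could not be told apart by this read-out. Chain length with the nitrile at its end reads the same way, with no change at the digits printed from compound 1 to compound 4 (within the scatter) and with no change at the digits printed from compound 2 to compound 4 (within the scatter), so the three nitrile compounds form a flat series across the chains shown. No measurement here accounts for this flat result.

The compounds shown leave open whether a carboxylic acid or an amine at the chain end, or a longer chain carrying the nitrile, would read differently from compound 4, which gives 10000 nM. They also leave open whether any change to the shared core would move the read-out at all.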